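The compounds below may be only part of what the source reports. "The series", "measured", "known", "first", "only" and "open" are said of these compounds alone.

In an ADME assay on HepG2 cells (Homo sapiens) for cytotoxicity, read by neutral red uptake, with a stated time of 24 h (on this read-out lower numbers stand for stronger inhibition and higher numbers for weaker inhibition), compound 1 (`CC(C)c1cc2c3c(c1OC(=O)CCl)OC(=O)[C@@]31CCCC(C)(C)[C@@H]1CC2`) gives 203000 nM and compound 2 (`CCCCC/C=C/C/C=C/CCCCCCCC(=O)Oc1c(C(C)C)cc2c3c1OC(=O)[C@@]31CCCC(C)(C)[C@@H]1CC2`) gives 289000 nM as its reading. Among the measured compounds shown here, these two numbers lie within the usual scatter of each other, so compound 1 stands level with the only other measured compound. For the measured compounds named here, no step between measured compounds that differ in one place is available for calibration.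

Still unmeasured is compound 3 (`CC(C)c1cc2c3c(c1OC(=O)c1cccnc1)OC(=O)[C@@]31CCCC(C)(C)[C@@H]1CC2`), which carries pyridin-3-yl in place of chloromethyl on a carbonyl carbon. The rest of the structure of compound 1 stays unchanged. Going by the values given here, the only guide is that compound 1 at 203000 nM and compound 2 at 289000 nM sit together within the scatter. Measurements of this exchange are absent, so no shift beyond the scatter is expected in this assay, and the expected step (a 1.0-fold lower number from compound 1 to compound 3 (0.01 log units; within the scatter)) has no preferred direction. For compound 3 the estimated value is 200000 nM (expected range 90000 nM to 420000 nM) in this read-out, and a reported limit in place of a number remains possible.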

Compound 3, half-maximal inhibitory concentration: 264000 nM
Estimate against measurement, compound 3: 1.3-fold (0.12 log units) below, within the range that was stated.
By their numbers in this assay, from the lowest: compounds 1, 3 and 2 (each within the scatter of the next).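

In this assay, among the compounds shown here, pyridin-3-yl in place of chloromethyl on a carbonyl carbon gives a 1.3-fold higher number from compound 1 to compound 3 (0.11 log units; within the scatter), the first step that can be read at a single place. At this place, therefore, a chloromethyl group with no ring and a pyridin-3-yl group with one six-membered aromatic ring and one hydrogen-bond acceptor give readings that lie within the scatter of each other, so this exchange does not separate compound 1 from compound 3 in this read-out. No measured evidence on the reason for this result is at hand.

Open, from the compounds shown here alone, is whether a group of another kind on the same carbonyl carbon, such as an aminomethyl group, a carboxylic acid or a phenyl ring without the ring nitrogen, would give a step beyond the scatter. Also open, going by these compounds, is whether an exchange elsewhere on the shared core, for example of the isopropyl group for a hydroxyl group or an amine, would move the reading at all in this assay.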